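The compounds below may be only part of what the source reports. "The series", "measured", "known", "first", "only" and "open" are said of these compounds alone.

Compound 1 `COc1cc(N)c(Cl)cc1NC(=O)C1CCN(CC2CC2)CC1` gives in a functional assay on the whole organism for antagonist activity, with Mus musculus as the target (a higher number here means that more compound is needed for the effect, a lower number that less compound is needed), only a limit, > 10 mg/kg.
Compound 2 `COc1cc(N)c(Cl)cc1NC(=O)C1CCN(C/C=C/c2ccccc2)CC1` gives in this assay only a limit, > 10 mg/kg.
Compound 3 `COc1cc(N)c(Cl)cc1NC(=O)C1CCN(Cc2ccc(OCc3ccccc3)cc2)CC1` gives in this assay only a limit, > 4 mg/kg.

Compound 3 thus stands nowhere on a numbered scale, since every value shown is a limit: the limit of > 10 mg/kg in this assay, at which 2 of the 3 values shown sit, and (the limit of > 4 mg/kg in this assay, at which 1 of the 3 values shown sits). No ordering among the three can be read from them. Compound 4 `COc1cc(N)c(Cl)cc1NC(=O)C1CCN(Cc2ccc(O)cc2)CC1` differs from compound 3 by a single change, (hydrogen in place of benzyl on an oxygen on an aromatic ring). For the measured compounds named here, the only measured step between neighbours, a step that the two limits leave unreadable from compound 1 to compound 2, is equally unreadable in size, so no step size can be carried over to this change, and no direction beyond the scatter is expected. Compound 4 is therefore expected close to the same limit, with a wide range, estimated at 6 mg/kg between 1.5 mg/kg and 30 mg/kg, which means an expected step that the limit leaves unreadable from compound 3 to compound 4.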

Compound 4, dose for half-maximal effect: > 8 mg/kg
Compound 4 gave a limit, no number; the forecaster's own chance of this, stated with the estimate: 70%; at least 1.3-fold (0.12 log units) between middle value and limit.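

Compound 4, like compounds 1, 2 and 3, gives only a limit in this assay, so its steps to compounds 1, 2 and 3 cannot be read. Still open, going by these compounds, is what dose any of the four actually needs for the effect.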